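A few compounds are considered here, and "the series" means these few. Any claim that something is new, unique, unknown or untested is made for them only; others in the source may bear on it.

Measured compounds in an assay for inhibition of Catechol O-methyltransferase (Rattus norvegicus), read by fluorescence and spectrophotometry; on this read-out higher numbers stand for weaker inhibition and lower numbers for stronger inhibition:
- compound 1 `O=C(/C=C/c1cccs1)c1cc(O)c(O)c([N+](=O)[O-])c1` gives 190 nM
- compound 2 `CC(=O)N1N=C(c2cc(O)c(O)c([N+](=O)[O-])c2)CC1c1cccs1` gives 210 nM
- compound 3 `N#Cc1ccc(/C=C/C(=O)c2cc(O)c(O)c([N+](=O)[O-])c2)cc1` gives 180 nM

All three compounds share the same nitro-bearing catechol core and differ only in the group attached to it. Compound 1 has the second highest of the three numbers, but its value lies within the scatter of both compound 3 and compound 2, so the three cannot be told apart on this evidence.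

Compound 4 `O=C(/C=C/c1ccoc1)c1cc(O)c(O)c([N+](=O)[O-])c1` is not yet measured. It differs from compound 1 in one place: furan-3-yl in place of thiophen-2-yl on a double-bonded chain carbon bound to a double-bonded chain carbon. For the measured compounds named here, no measured pair shows a step of this kind, so the expectation rests on the narrow spread seen so far. The step from compound 1 to compound 4 is expected to be small, a 1.3-fold higher number from compound 1 to compound 4 (0.12 log units; within the scatter), with no direction beyond the scatter. Compound 4 is estimated at 250 nM, within a range of 120 nM to 520 nM.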

Compound 4, half-maximal inhibitory concentration: 290 nM
Compound 4: the middle estimate sits 1.2-fold (0.06 log units) below what was measured; the measured number falls inside the stated range.
By their numbers in this assay, from the lowest: compounds 3, 1, 2 and 4 (each within the scatter of the next).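

In this assay, furan-3-yl in place of thiophen-2-yl on a double-bonded chain carbon bound to a double-bonded chain carbon gives a 1.5-fold higher number from compound 1 to compound 4 (0.18 log units; within the scatter) and so cannot be told apart from no change. For the compounds shown here, this is the first one-place comparison, and it shows that one five-membered aromatic ring can replace another at this place without a step beyond the scatter. Nothing measured here speaks to why the two compounds read alike.

Still open, from the compounds shown here alone, is whether an amine, a carboxylic acid or a longer chain at this place would give a step beyond the scatter.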